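The source may hold more compounds than are shown below. What is called first, only, known or untested is meant among the compounds shown, and "the series" means these compounds.

Values in a physicochemical assay for solubility, read by HPLC, in phosphate buffer, at pH 6.5 (on this read-out higher numbers stand for higher solubility and lower numbers for lower solubility), for the three measured compounds:

- compound 1 `COC(=O)C1=C(CN2CCNC(=O)C2)NC(c2nccs2)=NC1(C)c1ccc(F)cc1` gives 34 ug/mL
- compound 2 `COC(=O)C1=C(CN2CCC(O)CC2)NC(c2nccs2)=NC1(C)c1ccc(F)cc1` gives 593 ug/mL
- compound 3 `COC(=O)C1=C(CN2CCC(F)(F)CC2)NC(c2nccs2)=NC1(C)c1ccc(F)cc1` gives < 1 ug/mL as a limit and not a number

Compound 3 stands at the limit of < 1 ug/mL in this assay, at which 1 of the 3 values shown sits, and so has only a limit and no number of its own. The measured steps that end there are an at least 34-fold lower number from compound 1 to compound 3 (1.53 log units; beyond the scatter) and an at least 590-fold lower number from compound 2 to compound 3 (2.77 log units; beyond the scatter) and both place it lowest of the three.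

Compound 4 `COC(=O)C1=C(CN(C)C2(C(=O)O)CC2)NC(c2nccs2)=NC1(C)c1ccc(F)cc1` has not yet been measured. It differs from compound 3 as follows: a group of 8 heavy atoms (5 carbon, 1 nitrogen, 2 oxygen; one three-membered non-aromatic ring of carbon only) in place of a group of 8 heavy atoms (5 carbon, 1 nitrogen, 2 fluorine; one six-membered non-aromatic ring with 1 hetero atom), on a saturated chain carbon bound to a double-bonded ring carbon

The two steps ending at compound 3 bear on this change when read in reverse, since each involves the same 4,4-difluoropiperidin-1-yl group at the same place. Among the measured compounds shown here, neither partner group is the one entering in compound 4, and a 17-fold higher number from compound 1 to compound 2 (1.24 log units; beyond the scatter) shows that the two partners themselves lie far apart. A large rise is nevertheless expected in this assay, guided by compound 1 at 34 ug/mL and compound 2 at 593 ug/mL as the values reached on leaving the difluoro group. The estimated step is an at least 400-fold higher number from compound 3 to compound 4 (2.60 log units; beyond the scatter) here.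

Compound 4 is expected at 400 ug/mL, with an estimated range from 80 ug/mL to 1200 ug/mL.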

Compound 4, solubility: > 510 ug/mL
Compound 4: no number, only a limit; the forecaster's own chance of this, stated with the estimate: 10%; at least 1.2-fold (0.10 log units) between middle value and limit.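

In this assay, the group with a three-membered ring of carbon only, set on a saturated chain carbon bound to a double-bonded ring carbon, gives an at least 510-fold higher number from compound 3 to compound 4 (2.70 log units; beyond the scatter), and it also gives an at least 15-fold higher number from compound 1 to compound 4 (1.17 log units; beyond the scatter). Compound 4 gives > 510 ug/mL, which is a limit of the assay and not a number. Until now only compound 2, with its 4-hydroxypiperidin-1-yl group, stood at the high end of the read-out at this place, and a group without a six-membered ring now stands there too, although the step between compound 2 and compound 4 cannot be read, so the two remain unordered.

The compounds shown leave open where compound 4 would fall if it had a number of its own, and so how far it lies from the other compounds. They also leave open how this assay would respond if a methyl ester or a primary amide replaced the carboxylic acid of compound 4, or if a four-membered ring of carbon replaced its three-membered ring.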